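A few compounds are considered here, and "the series" means these few. Any claim that something is new, unique, unknown or untested is made for them only; others in the source may bear on it.

Measured compounds:
- compound 1 `Cc1cccc(NC(=O)c2ccc3cccc(O)c3n2)c1`: > 30000 nM
- compound 2 `Cc1ccc(NC(=O)c2ccc3cccc(O)c3n2)cc1`: > 30000 nM
- compound 3 `O=C(Nc1ccc(Cl)cc1)c1ccc2cccc(O)c2n1`: > 30000 nM

In an ADME assay on THP-1 cells (Homo sapiens) for cytotoxicity, read by WST assay, with a stated time of 24 h (on this read-out higher numbers stand for weaker inhibition and lower numbers for stronger inhibition), compound 1 gives > 30000 nM, which is a limit of the assay and not a number. Compound 2 likewise gives only the limit > 30000 nM. Compound 3 too gives only the limit > 30000 nM. Compound 1 therefore stands nowhere that can be placed on a scale: it shares the limit with both other compounds, as shown by the limit of > 30000 nM in this assay, at which 3 of the 3 values shown sit. The three steps among the measured compounds, a step that the two limits leave unreadable from compound 1 to compound 2, a step that the two limits leave unreadable from compound 1 to compound 3 and a step that the two limits leave unreadable from compound 2 to compound 3, are all left unreadable by the limits on either side.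

Compound 4 `O=C(Nc1ccc(Br)cc1)c1ccc2cccc(O)c2n1` has not yet been measured in this assay. It differs from compound 1 as follows: 4-bromophenyl in place of 3-methylphenyl on an amide-type nitrogen. Going by the values given here, the nearest measured step is the one from compound 1 to compound 3, where a 4-chlorophenyl replaces the 3-methylphenyl, and that step ends at the same limit as it starts. Among the compounds with values here, no step in this set shows any change beyond the scatter, so none is expected here either, in either direction; the most likely outcome is that compound 4 again reaches only the limit. On that basis compound 4 is expected to give about 45000 nM, within 20000 nM to 120000 nM, in this assay. The expected step is a step that the limit leaves unreadable from compound 1 to compound 4.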

Compound 4, half-maximal inhibitory concentration: > 30000 nM
Compound 4: no number, only a limit; the forecaster's own chance of this, stated with the estimate: 85%; the middle value lies beyond the limit too.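

The steps from compound 1, compound 2 and compound 3 to compound 4 cannot be read, as all four compounds share a single limit of the assay and no number: the limit of > 30000 nM in this assay, at which 4 of the 4 values shown sit.

The compounds shown leave open whether any change on the amide-type nitrogen would give a readable value in this assay, and whether these four compounds differ from one another at all.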